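Swapping hydroxy for cyano on a shared core

A few compounds are considered here, and "the series" means these few. Any claim that something is new, unique, unknown or untested is made for them only; others in the source may bear on it.

Of the compounds shown here, three sharing one core have been tested in an ADME assay on HEL cells (Homo sapiens) for cytotoxicity, with a stated time of 3 days; a higher number here means that more compound is tolerated, a lower number that less compound is tolerated. Compound 1 `Cc1cc(-c2ccsc2)c2ncc(CSCCc3ccccc3)n2c1` reaches the limit of the assay, giving > 50 ug/mL. Compound 2 `Cc1cc(-c2ccc(O)cc2)cn2c(CSCCc3ccccc3)cnc12` also returns only a limit, > 50 ug/mL, so no exact number is known for it. Among the compounds with values here, compound 3 `COc1ccc(-c2cc(C)cn3c(CSCCc4ccccc4)cnc23)cc1` gives 19.6 ug/mL in this assay, and the one measured step, an at least 2.5-fold lower number from compound 1 to compound 3 (0.40 log units; beyond the scatter), is the only change with a size attached. Two of the three values sit at the limit of > 50 ug/mL in this assay, at which 2 of the 3 values shown sit, so compound 2 stands with compound 1 at the edge of what the assay can report, while compound 3 lies below that edge.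

Compound 4 `Cc1cc(-c2ccc(C#N)cc2)cn2c(CSCCc3ccccc3)cnc12` has not been measured yet. It differs from compound 2 by cyano in place of hydroxy on an aromatic carbon. Within the data shown here, no measured step covers this exact change; the step from compound 1 to compound 3 alters a different part of the molecule and moved the number at least modestly downward, which bears on it only loosely. Given that compound 2 sits at a limit, compound 4 is expected to show a step of about an at least 1.6-fold lower number from compound 2 to compound 4 (0.22 log units; that floor lies within the scatter) in this assay, possibly none beyond the scatter. The estimate for compound 4 is therefore 30 ug/mL, with a range from 12 ug/mL to 60 ug/mL.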

Compound 4, half-maximal cytotoxic concentration: 10.6 ug/mL
Compound 4: middle estimate off by 2.8-fold (0.45 log units), on the high side, outside the stated range (below it).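

Compound 2 gives > 50 ug/mL, which is a limit of the assay and not an exact number. Within the data shown here, changing only the group on the aromatic carbon para to a large group, with cyano in place of hydroxy, gives an at least 4.7-fold lower number from compound 2 to compound 4 (0.67 log units; beyond the scatter) in this assay; the earlier measured step altered a different part of the molecule, so this is the first sign that the group at this place on the phenyl ring can shift how much compound the cells tolerate. This step is only a floor, and its full size cannot be read, because compound 2 sits at the edge of what the assay reports: the limit of > 50 ug/mL in this assay, at which 2 of the 4 values shown sit.

Hydroxy carries a hydrogen-bond donor and cyano does not, while cyano brings a triple bond and one more heavy atom, so these compounds cannot tell which of these differences goes with the lower number. Also open, going by these compounds, is how other groups at this same place, such as an amine, a carboxylic acid or a chlorine atom, would compare, and whether the same swap would move the number on a different part of the molecule.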